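This account rests on a few compounds, and the source may have more. Where it says the series, first, only, none or still open, it means among the compounds named here.

In an ADME assay on cells (Hepatocyte, Rattus norvegicus) for metabolic stability, read by LC-MS, with a stated time of 60 min (a higher number here means that more of the compound is left, a lower number that less of the compound is left), compound 1 (`C[C@@H]1CC(c2cnc3c(C#N)nn([C@H](C)c4ccc(Cl)cc4Cl)c3n2)=CC[C@@H]1N1CCC[C@H]1CO`) gives 32% and compound 2 (`Cc1nn([C@H](C)c2ccc(Cl)cc2Cl)c2nc(C3=CC[C@H](N4CCC[C@H]4CO)[C@H](C)C3)cnc12`) gives 35%, two values within the scatter of each other. Compound 3 (`C[C@@H]1CC(c2cnc3c(C#N)nn([C@H](C)c4ccc(Cl)cc4Cl)c3n2)=CC[C@@H]1N1CCC[C@H]1C`) differs from compound 1 as follows: hydrogen in place of hydroxy on a saturated chain carbon bound to a saturated ring carbon, which turns hydroxymethyl into methyl. Among the compounds with values here, the only measured step, a number 3 percentage points higher from compound 1 to compound 2 (within the scatter), lies at another place, so nothing measured tests this change directly. No step beyond the scatter is therefore expected in this assay, and no direction is favoured. The estimated step is a number 2 percentage points lower from compound 1 to compound 3 (within the scatter). For compound 3 the expected value is 30%, with an estimated range of 14% to 48%.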

Compound 3, percent of the compound remaining: 72%
Compound 3: the middle estimate sits 42 percentage points below what was measured; the whole stated range lies below it.
By their numbers in this assay, from the lowest: compounds 1 and 2 (each within the scatter of the next); then compound 3.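

In this assay, hydrogen in place of hydroxy on a saturated chain carbon bound to a saturated ring carbon, which turns hydroxymethyl into methyl, brings a number 40 percentage points higher from compound 1 to compound 3 (beyond the scatter). Within the data shown here, the earlier pair differed only on an aromatic carbon, with a number 3 percentage points higher from compound 1 to compound 2 (within the scatter), so this is the first step beyond the scatter and it places the sensitivity of the read-out at this side group. Nothing measured here accounts for the step. From the compounds shown here alone, it remains open whether the same change would carry over to compound 2, and how a methoxymethyl group or a carboxylic acid would fare at this place.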